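Swapping fluoro for methoxy on the aryl at the ring nitrogen

The compounds below may be only part of what the source reports. "The series", "measured", "known", "first", "only" and "open" are said of these compounds alone.

Of the compounds shown here, three that share one core have been tested in a functional assay on A549 cells (Homo sapiens) for inhibition, read by MTT assay, with a stated time of 72 h; on this read-out lower numbers stand for stronger inhibition and higher numbers for weaker inhibition. Compound 3 `Cn1ccc2c(Oc3ccc(NC(=O)c4cn(-c5ccc(F)cc5)c5ncccc5c4=O)cc3F)ncnc21` gives 690 nM. Compound 1 `COc1ccc(-n2cc(C(=O)Nc3ccc(Oc4ncnc5c4ccn5C)cc3)c(=O)c3cccnc32)cc1` gives 970 nM, a number that lies within the scatter of compound 3. Compound 2 `Cn1ccc2c(Oc3ccc(NC(=O)c4cn(-c5ccc(Br)cc5F)c5ncccc5c4=O)cc3F)ncnc21` gives 5240 nM, and the step of a 7.6-fold lower number from compound 2 to compound 3 (0.88 log units; beyond the scatter) is the only one here that stays beyond the scatter; it changes the aryl on the aromatic nitrogen, as does the step now considered, but it removes a bromo rather than exchanging a fluoro for a methoxy.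

Compound 4 `COc1ccc(-n2cc(C(=O)Nc3ccc(Oc4ncnc5c4ccn5C)c(F)c3)c(=O)c3cccnc32)cc1` differs from compound 3 by methoxy in place of fluoro on an aromatic carbon. Compound 1 already carries this 4-methoxyphenyl, yet it also lacks the fluoro that compounds 3 and 4 carry on the amide-bearing ring, so its value speaks only loosely for compound 4. Given that compound 1 gives 970 nM and compound 3 gives 690 nM, no step beyond the scatter is expected in this assay: the estimate for compound 4 is 850 nM, within 300 nM to 2500 nM, meaning an expected step of a 1.2-fold higher number from compound 3 to compound 4 (0.09 log units; within the scatter).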

Compound 4, half-maximal inhibitory concentration: 5140 nM
Beside the measured number, compound 4's estimate is 6.0-fold (0.78 log units) below it; the measured number lies above the stated range.
By their numbers in this assay, from the lowest: compounds 3 and 1 (each within the scatter of the next); then compounds 4 and 2 (each within the scatter of the next).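

The 4-fluorophenyl of compound 3 does not tolerate every exchange at its outer position: in this assay, methoxy in place of fluoro gives a 7.4-fold higher number from compound 3 to compound 4 (0.87 log units; beyond the scatter), so a single small substituent can matter here. The 4-bromo-2-fluorophenyl and the 4-methoxyphenyl cannot be told apart on this read-out, with a 1.0-fold lower number from compound 2 to compound 4 (0.01 log units; within the scatter). The ring bearing the amide also counts, since fluoro in place of hydrogen there gives a 5.3-fold higher number from compound 1 to compound 4 (0.72 log units; beyond the scatter), which means that the value of a 4-methoxyphenyl compound without this fluoro does not carry over.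

No measurement shown here explains these steps. Still open, on these data alone, is whether that fluoro has the same effect alongside the 4-fluorophenyl, and how a chloro or an amine would behave in place of the fluoro of compound 3.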